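The source may report more compounds than this note shows. Statements on the series, on what has been measured and on what is new or still open speak of the compounds shown alone.

Measured in a functional assay on KMS-11 cells (Homo sapiens) for antiproliferative activity, read by CellTiter-Glo, with a stated time of 72 h; on this read-out higher numbers stand for weaker inhibition and lower numbers for stronger inhibition:
- compound 1 `COc1ccc(C(=O)N(Cc2ccncc2)Cc2cccc(OCCc3cccc(C(F)(F)F)c3)c2)cc1`: 8900 nM
- compound 2 `COc1ccc(C(=O)N(Cc2ccncc2)Cc2cccc(OCc3ccc([N+](=O)[O-])cc3)c2)cc1`: 15400 nM

On these numbers compound 2 cannot be separated from compound 1, the step being a 1.7-fold higher number from compound 1 to compound 2 (0.24 log units; within the scatter). Compound 3 `COc1ccc(C(=O)N(Cc2ccncc2)Cc2cccc(OCC(=O)c3ccc(Cl)cc3)c2)cc1` keeps the shared core and differs from compound 2 at that same place. It carries (4-chlorophenyl)carbonyl in place of 4-nitrophenyl on a saturated chain carbon bound to an oxygen on an aromatic ring. Cut one bond further out, this reads 4-nitrobenzyl to ((4-chlorophenyl)carbonyl)methyl.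

Going by the values given here, only one measured step bears on this change, and it exchanges a group at the same place: a 1.7-fold higher number from compound 1 to compound 2 (0.24 log units; within the scatter). Among the compounds with values here, no measured compound has a carbonyl in this chain or a chlorine, so this is thin evidence. Even so, the expectation in this assay is for no step beyond the scatter, and no direction can be favoured with confidence. The expected change is a 1.3-fold lower number from compound 2 to compound 3 (0.11 log units; within the scatter). For compound 3 the estimated value is 12000 nM, with an expected range of 4500 nM to 30000 nM.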

Compound 3, half-maximal inhibitory concentration: 18500 nM
The estimate for compound 3 lay 1.5-fold (0.19 log units) below the measured number; the measured number falls inside the stated range.
By their numbers in this assay, from the lowest: compounds 1, 2 and 3 (each within the scatter of the next, the first and the last beyond it).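

In this assay, the (4-chlorophenyl)carbonyl group brings both a carbonyl and a chlorine to this place on the chain, yet replacing 4-nitrophenyl with it gives only a 1.2-fold higher number from compound 2 to compound 3 (0.08 log units; within the scatter) and so does not separate compound 3 from compound 2. Set against the 3-(trifluoromethyl)benzyl group, the same group gives a 2.1-fold higher number from compound 1 to compound 3 (0.32 log units; beyond the scatter) and this is the first step at this position to pass the scatter, though only modestly, while compound 2 remains inseparable from either neighbour. No measurement is available that would explain why these groups behave as they do at this place.

Compound 3 carries its carbonyl and its chlorine together, so the compounds shown leave open which of the two, if either, goes with its step from compound 1. Also open, on these data alone, is whether an amine or a carboxylic acid at this place would move the number well outside the span of these three compounds, in either direction.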